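A few compounds are considered here, and "the series" means these few. Any claim that something is new, unique, unknown or untested is made for them only; others in the source may bear on it.

Compound 1 `C#CCNC1CCc2c(OCCCCCCN3CCN(c4cccc5c4ccn5Cc4cccc(Cl)c4)CC3)cccc21` gives 259 nM.
Compound 2 `C[C@H](NCc1ccc(OCCCCCCN2CCN(c3cccc4c3ccn4Cc3cccc(Cl)c3)CC2)cc1)C(N)=O` gives 340 nM.
Compound 3 `C[C@H](NCc1ccc(OCCCCN2CCN(c3cccc4c3ccn4S(=O)(=O)c3ccccc3)CC2)cc1)C(N)=O` gives 68 nM.

All three numbers come from an assay on HEK293 cells for displacement of a labelled ligand from 5-hydroxytryptamine receptor 6 (Homo sapiens), read by scintillation counting, with a stated time of 1 h; a higher number here means a weaker inhibitor, a lower number a stronger inhibitor. Compound 3 stands lowest of the three, and its gaps to compound 1 and to compound 2 both lie beyond the scatter, so it is the strongest binder shown. Compound 4 `C#CCN(C)Cc1ccc(OCCCCN2CCN(c3cccc4c3ccn4S(=O)(=O)c3ccccc3)CC2)cc1` has not yet been run in this assay; it differs from compound 3 by methyl(propargyl)amino in place of (1-carbamoylethyl)amino on a saturated chain carbon bound to an aromatic carbon. For the measured compounds named here, no single-point step between measured compounds covers this exchange. Compound 1 and compound 2, which carry the two kinds of amine on a different core, show numbers close to each other. The step from compound 3 to compound 4 is therefore expected to be small, a 1.5-fold higher number from compound 3 to compound 4 (0.17 log units; within the scatter), not beyond the scatter. Compound 4 is estimated at 100 nM, within 30 nM to 350 nM.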

Compound 4, inhibition constant: 54 nM
Estimate against measurement, compound 4: 1.9-fold (0.27 log units) above; the range from low to high includes it.
By their numbers in this assay, from the lowest: compounds 4 and 3 (each within the scatter of the next); then compounds 1 and 2 (each within the scatter of the next).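

In this assay, the exchange of (1-carbamoylethyl)amino for methyl(propargyl)amino on a saturated chain carbon bound to an aromatic carbon gives a 1.3-fold lower number from compound 3 to compound 4 (0.10 log units; within the scatter). For the compounds shown here, this is the first comparison of the two amines that differs in one place, and it shows that the hydrogen-bond donors and the defined stereocentre of (1-carbamoylethyl)amino can be lost here without a change beyond the scatter. No measurement offers an explanation for this result. Left open is how a dimethylamino group or a carboxylic acid would read on this saturated chain carbon.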